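Compound 3 to compound 4: replacing the 4-(trifluoromethyl)phenyl group

The source may hold more compounds than are shown below. What is called first, only, known or untested is meant among the compounds shown, and "the series" means these compounds.

In a functional assay on MCF7 cells (Homo sapiens) for inhibition, read by sulforhodamine B assay (on this read-out higher numbers stand for weaker inhibition and lower numbers for stronger inhibition), compound 3 (`O=C1C=C(Nc2ccc(C(F)(F)F)cc2)C(=O)c2c1nc1n2[C@H]2OC[C@@H](O)[C@H]2OC1`) gives > 4000 nM and this value is a limit of the assay, not a number.

Two relatives on the shared core give numbers in this assay as well: compound 1 (`CCc1ccc(NC2=CC(=O)c3nc4n(c3C2=O)[C@H]2OC[C@@H](O)[C@H]2OC4)cc1`) gives 960 nM and compound 2 (`O=C1C=C(Nc2cccc(F)c2)C(=O)c2c1nc1n2[C@H]2OC[C@@H](O)[C@H]2OC1`) gives 5500 nM on the same read-out. From the compounds shown here alone, compound 3 therefore stands on the weak side of this small set, though its exact place is unknown, and the comparison with compound 2 yields no readable size (a step that the limit leaves unreadable from compound 2 to compound 3).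

Compound 4 (`Cc1ccc(NC2=CC(=O)c3nc4n(c3C2=O)[C@H]2OC[C@@H](O)[C@H]2OC4)cc1C`) carries 3,4-dimethylphenyl in place of 4-(trifluoromethyl)phenyl on an amine nitrogen. Like the 4-ethylphenyl of compound 1, this group holds no fluorine. For the measured compounds named here, both fluorine-bearing compounds read higher than compound 1, as the two measured steps show (a 5.7-fold higher number from compound 1 to compound 2 (0.76 log units; beyond the scatter)) and (an at least 4.1-fold higher number from compound 1 to compound 3 (0.61 log units; beyond the scatter)), and no compound here goes against that, though three compounds make a thin basis. Compound 4 is thus expected to read lower than compound 3, by a modest amount that partly reverses the second of those steps. The expected move is (an at least 2.6-fold lower number from compound 3 to compound 4 (0.42 log units; beyond the scatter)) in this assay as an estimate only. Compound 4 is estimated at 1500 nM with a range of 500 nM to 4500 nM as the expected span.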

Compound 4, half-maximal inhibitory concentration: 2080 nM
Compound 4: the middle estimate sits 1.4-fold (0.14 log units) below what was measured, and the stated range covers the measured number.
By their numbers in this assay, from the lowest: compound 1; then compound 4; then compound 2.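

In this assay, 3,4-dimethylphenyl on the amine nitrogen shows that two aromatic groups without fluorine need not read alike at this position, with a 2.2-fold higher number from compound 1 to compound 4 (0.34 log units; beyond the scatter), so the absence of fluorine does not by itself set the number, while the same group still reads on the lower side of a fluorine-bearing neighbour, with a 2.6-fold lower number from compound 2 to compound 4 (0.42 log units; beyond the scatter). Against the trifluoromethyl-bearing group, the change gives an at least 1.9-fold lower number from compound 3 to compound 4 (0.28 log units; that floor lies within the scatter), so the change of 4-(trifluoromethyl)phenyl to 3,4-dimethylphenyl is not established as a shift beyond the usual scatter, since only its floor can be read. Compound 3 remains a limit of the assay and not a number: the limit of > 4000 nM in this assay, at which 1 of the 4 values shown sits.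

From the compounds shown here alone, the true place of compound 3 stays open, and the steps that rest on its limit alone cannot be read, which leaves the order among the fluorine-bearing groups unsettled. Also open, going by these compounds, is how this position responds to an unsubstituted phenyl, a methoxy-bearing phenyl, a phenyl carrying a carboxylic acid or an amine, or a chain longer than the ethyl of compound 1.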